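Notes on compound 4: one chloro removed from compound 2

The source may hold more compounds than are shown below. What is called first, only, known or untested is meant among the compounds shown, and "the series" means these compounds.

compound 1 `CC(C)[C@H](NC(=O)c1ccc(Cl)cc1O)C(=O)Nc1ccc(Br)cc1`: in a functional assay on MCF7 cells (Homo sapiens) for cytotoxicity, with a stated time of 72 h (a lower number here means a stronger inhibitor, a higher number a weaker inhibitor), compound 1 gives > 10000 nM, a limit of the assay.
compound 2 `CC(C)[C@H](NC(=O)c1ccc(Cl)cc1O)C(=O)Nc1ccc(Cl)c(Cl)c1`: in this assay compound 2 gives > 10000 nM, a limit of the assay.
compound 3 `CC(C)[C@H](NC(=O)c1cc(Cl)ccc1O)C(=O)Nc1ccc(Cl)c(Cl)c1`: in this assay compound 3 gives > 10000 nM, a limit of the assay.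

Compound 2 sits at the limit, as do both other values (the limit of > 10000 nM in this assay, at which 3 of the 3 values shown sit). Compound 4 `CC(C)[C@H](NC(=O)c1ccc(Cl)cc1O)C(=O)Nc1ccc(Cl)cc1` differs from compound 2 by hydrogen in place of chloro on an aromatic carbon. The two steps measured so far, a step that the two limits leave unreadable from compound 1 to compound 2 and a step that the two limits leave unreadable from compound 2 to compound 3, are unreadable between limits, so neither gives a size to carry over to the ring that compound 4 changes. The expectation for compound 4 in this assay is therefore another limit, with no readable step that the limit leaves unreadable from compound 2 to compound 4. Compound 4 is estimated at 20000 nM, within 8000 nM to 60000 nM.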

Compound 4, half-maximal inhibitory concentration: > 10000 nM
Compound 4: no number, only a limit; the forecaster's own chance of this, stated with the estimate: 85%; the middle value lies beyond the limit too.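

The steps to compound 4 from compound 1 and from compound 2 cannot be read, with all the compounds at one limit: the limit of > 10000 nM in this assay, at which 4 of the 4 values shown sit.

The compounds shown leave open whether any change to this series gives a measurable value in this assay.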